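A small swap on the way to compound 4

The source may hold more compounds than are shown below. What is called first, only, known or untested is meant among the compounds shown, and "the series" means these compounds.

Measured in an ADME assay on microsomes from liver (Homo sapiens) for metabolic stability; a lower number here means slower removal, a higher number faster removal of the compound:
compound 1 `Cc1ccc(-c2c(-c3nn(C)c4ncnc(N5CCC5)c34)cnn2C)cc1` gives 47 mL/min/kg
compound 2 `Cn1ncc(-c2nn(C)c3ncnc(N4CCC4)c23)c1-c1ccccc1` gives 34 mL/min/kg
compound 3 `Cn1ncc(-c2nn(C)c3ncnc(N4CCC4)c23)c1-c1ncc(C2CC2)cn1` gives 28 mL/min/kg

Compound 3 at 28 mL/min/kg sits within the scatter of both other compounds, so these three values do not separate. Compound 4 `Cn1ncc(-c2nn(C)c3ncnc(N4CCC4)c23)c1-c1ccc(C2CC2)cn1` has yet to be measured. It carries 5-cyclopropylpyridin-2-yl in place of 5-cyclopropylpyrimidin-2-yl on an aromatic carbon and otherwise matches compound 3.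

Among the measured compounds shown here, no measured pair shows this exact swap. The nearest evidence comes from replacing the whole group at that place. That gave a 1.2-fold lower number from compound 2 to compound 3 (0.08 log units; within the scatter) and also a 1.7-fold lower number from compound 1 to compound 3 (0.22 log units; within the scatter) and both lie within the scatter. Removing the methyl gave a 1.4-fold lower number from compound 1 to compound 2 (0.14 log units; within the scatter) and that too lies within the scatter. In this assay no step beyond the scatter is therefore expected for compound 4, and these data do not settle a direction. The expected change is a 1.1-fold higher number from compound 3 to compound 4 (0.03 log units; within the scatter) and this stays within the scatter. For compound 4 the estimate is 30 mL/min/kg with an expected range from 19 mL/min/kg to 46 mL/min/kg in this measurement.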

Compound 4, clearance: 53 mL/min/kg
The estimate for compound 4 lay 1.8-fold (0.25 log units) below the measured number, outside the stated range (above it).
By their numbers in this assay, from the lowest: compounds 3, 2, 1 and 4 (each within the scatter of the next).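

In this assay, exchanging one ring nitrogen of the six-membered ring for carbon gives a 1.9-fold higher number from compound 3 to compound 4 (0.28 log units; within the scatter) and so makes the largest step seen at this place, even though it stays within the scatter. Against the simpler rings, the new group gives a 1.6-fold higher number from compound 2 to compound 4 (0.19 log units; within the scatter) and a 1.1-fold higher number from compound 1 to compound 4 (0.05 log units; within the scatter) and so leaves all four groups unseparated, yet the change of a single ring atom produces a step no smaller than those from replacing the whole group. Nothing available here explains this step.

As far as these compounds go, whether a group from outside this set, such as an amine or a carboxylic acid in place of the cyclopropyl, would give a step beyond the scatter remains open. From the compounds shown here alone, the role of the cyclopropyl itself is also open, since every ring that carries it here keeps it in the same place.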